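Benzimidazole to imidazole swap on the pyridazinone-arylpiperazine series

This account rests on a few compounds, and the source may have more. Where it says the series, first, only, none or still open, it means among the compounds named here.

Two cores carry the same pair of end groups. Compound 1 `O=c1ccc(-n2cnc3ccccc32)nn1CCCCN1CCN(c2ccccc2Cl)CC1` and compound 2 `O=c1ccc(-n2cnc3ccccc32)nn1CCCCCN1CCN(c2ccccc2Cl)CC1` differ in the chain joining the two ring systems; the difference between the two cores is not broken down here. In an assay on cell membranes from brain for binding affinity to Adrenergic receptor alpha-1 (Rattus norvegicus), read by radioligand binding (on this read-out higher numbers stand for weaker inhibition and lower numbers for stronger inhibition), compound 1 gives 1.3 nM, and compound 2 gives 4.5 nM, the two differing beyond the usual scatter. Compound 3 `O=c1ccc(-n2ccnc2)nn1CCCCN1CCN(c2ccccc2Cl)CC1` is compound 1 after the change (1H-imidazol-1-yl in place of 1H-benzimidazol-1-yl on an aromatic carbon), and in this assay compound 3 gives 24.6 nM; the step is a 19-fold higher number from compound 1 to compound 3 (1.28 log units; beyond the scatter).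

Compound 4 `O=c1ccc(-n2ccnc2)nn1CCCCCN1CCN(c2ccccc2Cl)CC1` is the not yet measured partner of compound 2 under the change (1H-imidazol-1-yl in place of 1H-benzimidazol-1-yl on an aromatic carbon). The place of the change is described in the same words for both pairs, so the two changes are the same kind of change, made on two cores. Within the data shown here, with only one measured instance of the change, the expectation for compound 4 rests on that single step and on compound 2 as the starting point.

Compound 4 is expected to show a step of about a 19-fold higher number from compound 2 to compound 4 (1.28 log units; beyond the scatter) in this assay, because the step of a 19-fold higher number from compound 1 to compound 3 (1.28 log units; beyond the scatter) was large. On that basis compound 4 is estimated at 85 nM, with a plausible range from 30 nM to 250 nM.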

Compound 4, inhibition constant: 23.3 nM
For compound 4 the middle estimate is 3.6-fold (0.56 log units) above the measured one, outside the stated range (below it).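

In this assay the change to 1H-imidazol-1-yl raises the number on the second core as well, a 5.2-fold higher number from compound 2 to compound 4 (0.71 log units; beyond the scatter), so the direction of the change carries over between the two cores shown. Among these compounds, the size of the step does not carry over, and the two steps stand apart beyond the scatter: the same change on two cores in this assay, a 19-fold higher number (1.28 log units; beyond the scatter) from compound 1 to compound 3 and a 5.2-fold higher number (0.71 log units; beyond the scatter) from compound 2 to compound 4, 3.7-fold (0.56 log units) apart, beyond the scatter of two such steps With only two pairs, this shows that a step measured on one core is a guide to direction but not a reliable figure for size on the other, and it does not show why the two steps differ or how the size would vary across the series.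

Still open, as far as these compounds go, is whether the step keeps the same direction, and what size it takes, on a core with a longer or a shorter chain. Also open, from the compounds shown here alone, is how an amine or a phenyl group in place of 1H-benzimidazol-1-yl would compare on these two cores.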